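Replacing Methyl by 4-Methylphenyl on the Chain of Compound 1

The compounds below may be only part of what the source reports. "The series", "measured", "known", "first", "only" and "open" are said of these compounds alone.

Among the compounds with values here, in an ADME assay on HEp-2 cells (Homo sapiens) for cytotoxicity, read by MTT assay, with a stated time of 3 days (on this read-out higher numbers stand for lower toxicity in this test and lower numbers for higher toxicity in this test), compound 1 `CC[C@H](CCn1cncn1)c1ccccc1` gives 97.7 ug/mL, and its only measured neighbour, compound 2 `CC[C@H](CCn1cncn1)c1ccc(C)cc1`, gives 75.2 ug/mL, so that the step of a 1.3-fold lower number from compound 1 to compound 2 (0.11 log units; within the scatter), methyl in place of hydrogen on an aromatic carbon, leaves the two compounds within the scatter of each other. Compound 3 `Cc1ccc(C[C@H](CCn2cncn2)c2ccccc2)cc1` differs from compound 1 by 4-methylphenyl in place of methyl on a saturated chain carbon, two bonds along the chain from an aromatic carbon. Within the data shown here, the single measured step concerns a much smaller change and bears only loosely on this one, so no firm direction follows from it. Compound 3 is estimated at 60 ug/mL, in a range from 25 ug/mL to 150 ug/mL, which means an expected step of a 1.6-fold lower number from compound 1 to compound 3 (0.21 log units; within the scatter).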

Compound 3, half-maximal cytotoxic concentration: 38.8 ug/mL
Compound 3: middle estimate off by 1.5-fold (0.19 log units), on the high side, and the stated range covers the measured number.
By their numbers in this assay, from the lowest: compounds 3, 2 and 1 (each within the scatter of the next, the first and the last beyond it).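

In this assay the exchange on the saturated chain carbon gives a 2.5-fold lower number from compound 1 to compound 3 (0.40 log units; beyond the scatter) and so a modest step beyond the scatter, which the methyl on the aromatic carbon did not produce. The chain position, two bonds along the chain from an aromatic carbon, is thus the first place shown where a change moves the number towards higher toxicity in this test. Nothing available explains this step.

Whether the methyl on the added ring contributes remains open, since a plain phenyl does not appear among these compounds. So does the effect of an amine or a carboxylic acid at this chain carbon.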